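A few compounds are considered here, and "the series" means these few. Any claim that something is new, unique, unknown or untested is made for them only; others in the source may bear on it.

In an ADME assay on Vero cells (Chlorocebus sabaeus) for cytotoxicity, with a stated time of 72 h (a higher number here means a weaker inhibitor, a lower number a stronger inhibitor), compound 1 `CCOC(=O)c1cc(/C=C/c2ccccc2)on1` has the result "not determined" (no result reported), so it offers no number to start from. For the measured compounds named here, the only other reading comes from compound 2 `CCOC(=O)c1cc(/C=C/c2cccc(OC)c2)on1`, which gives > 128000 nM, and this is a limit of the assay and not a number. Compound 3 `CCOC(=O)c1cc(/C=C/c2ccco2)on1` has yet to be measured. It differs from compound 1 by furan-2-yl in place of phenyl on a double-bonded chain carbon bound to a double-bonded chain carbon, with furan-2-yl in place of phenyl. Resting on the limit of compound 2 at > 128000 nM, no step beyond the usual scatter is expected in this assay, in either direction. Compound 3 is estimated at 128000 nM, within a range of 50000 nM to 256000 nM.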

Compound 3, half-maximal inhibitory concentration: > 128000 nM
Compound 3 gave a limit, no number; the forecaster's own chance of this, stated with the estimate: 70%; the middle value sits exactly at the limit.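

Compound 3 gives only a limit of the assay and compound 1 gives no number, so no step can be read between them. On these data alone, what the change from phenyl to furan-2-yl does in this assay stays open.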